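The compounds below may be only part of what the source reports. "The series", "measured", "known", "first", "only" and "open" are said of these compounds alone.

Working notes on the series. Compound 1 `CC(C)n1cc(C(=O)C(=O)Nc2ccc(C(F)(F)F)nc2)c2ccccc21` is tested in a functional assay on FaDu cells (Homo sapiens) for cytotoxicity, read by MTT assay, with a stated time of 72 h; a higher number here means that more compound is tolerated, a lower number that less compound is tolerated. In this assay compound 1 gives only a limit, > 10000 nM, not a number; this is one of the two values shown and sits at the limit of > 10000 nM in this assay, at which 1 of the 2 values shown sits. Compound 2 `CCCCn1cc(C(=O)C(=O)Nc2ccc(OC)nc2)c2ccccc21` is the other measured member and differs from compound 1 in two places at once; in this assay compound 2 gives 18 nM. The two values show a wide gap, but no single step connects them, so nothing of its size or cause can be split between the two changes.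

Compound 3 `CC(C)n1cc(C(=O)C(=O)Nc2cccnc2)c2ccccc21` is not yet measured. It differs from compound 1 by hydrogen in place of trifluoromethyl on an aromatic carbon. Within the data shown here, no measured step of this kind stands in the set, so the direction rests on the two values shown alone: compound 1 sits at the limit, compound 2 far from it, and the expectation is for a lower number than the limit of compound 1, by a step that is more than the scatter but uncertain in size. The estimated step from compound 1 to compound 3 is an at least 4.0-fold lower number from compound 1 to compound 3 (0.60 log units; beyond the scatter). For compound 3 the estimate in this assay is 2500 nM, expected to fall between 300 nM and 10000 nM.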

Compound 3, concentration lethal to 50% of the cells: > 10000 nM
Compound 3: a limit, no number; the forecaster's own chance of this, stated with the estimate: 35%; middle value at least 4.0-fold (0.60 log units) from the limit.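

In this assay compound 3, like compound 1, gives only a limit and not a number, so no step can be read between the two: the limit of > 10000 nM in this assay, at which 2 of the 3 values shown sit.

The compounds shown leave open whether hydrogen in place of trifluoromethyl on an aromatic carbon changes the value in this assay at all, and in which direction.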